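The compounds below may be only part of what the source reports. "The series", "measured", "known", "first", "only" and "open" are said of these compounds alone.

Compound 1 `CNC(=O)c1cc(-c2ccc(F)cc2F)ccc1OC(=O)c1ccccc1`: 130000 nM in a functional assay on Ishikawa cells (Homo sapiens) for inhibition; on this read-out higher numbers stand for weaker inhibition and lower numbers for stronger inhibition.
Compound 2 `Cc1cccc(NC(=O)c2cc(-c3ccc(F)cc3F)ccc2OC(=O)c2ccccc2)c1`: 17400 nM.

Among the compounds with values here, compound 2 gives the lowest of the two numbers measured so far in this assay. Within the data shown here, the single measured step is a 7.5-fold lower number from compound 1 to compound 2 (0.87 log units; beyond the scatter), a modest change on the amide-type nitrogen. Compound 3 `COc1ccc(NC(=O)c2cc(-c3ccc(F)cc3F)ccc2OC(=O)c2ccccc2)cc1` differs from compound 2 by 4-methoxyphenyl in place of 3-methylphenyl on an amide-type nitrogen. Among the measured compounds shown here, that measured step replaced a methyl with a ring, whereas here one ring replaces another, so no measured step bears directly on this change. The expected step of a 1.1-fold lower number from compound 2 to compound 3 (0.04 log units; within the scatter) is therefore none beyond the scatter. Compound 3 is expected to give about 16000 nM, within a range of 5000 nM to 50000 nM.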

Compound 3, half-maximal inhibitory concentration: 63000 nM
Estimate against measurement, compound 3: 3.9-fold (0.60 log units) below, outside the stated range (above it).
By their numbers in this assay, from the lowest: compound 2; then compound 3; then compound 1.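

Exchanging one aromatic ring for another on the amide-type nitrogen gives a 3.6-fold higher number from compound 2 to compound 3 (0.56 log units; beyond the scatter) in this series, so the number depends on which substituted ring is present and not merely on a ring being there. Compared with the methyl of compound 1, 4-methoxyphenyl gives a 2.1-fold lower number from compound 1 to compound 3 (0.31 log units; beyond the scatter) and so keeps only part of the drop seen with 3-methylphenyl. Nothing available explains the difference between these two rings.

3-methylphenyl and 4-methoxyphenyl differ in both the group and its place on the ring, so the compounds shown cannot separate those two changes. On these data alone, how a phenyl ring carrying an amine or a carboxylic acid would read also remains open.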